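The source may report more compounds than this note shows. Statements on the series, on what has been measured and on what is new or still open speak of the compounds shown alone.

Measured compounds:
compound 1, `Fc1ccc(-c2cc(-c3ccc4cc(F)ccc4n3)n(-c3ccccc3)n2)cc1`, 88.1%
compound 2, `COc1ccc(-c2cc(-c3ccc4cc(F)ccc4n3)n(-c3ccccc3)n2)cc1`, 104%
compound 3, `NS(=O)(=O)c1ccc(-n2nc(-c3ccc(F)cc3)cc2-c2ccc3cc(F)ccc3n2)cc1`, 91.1%

In an ADME assay on Huh-7 cells (Homo sapiens) for cytotoxicity, read by XTT assay, with a stated time of 3 days, tested at 20 uM (a higher number here means a weaker effect of the compound at the concentration tested, a lower number a stronger effect), compound 1 gives 88.1%. Compound 2 is its neighbour with methoxy in place of fluoro on an aromatic carbon, and in this assay compound 2 gives 104%, so that the step of a number 15.9 percentage points higher from compound 1 to compound 2 (beyond the scatter). Compound 3 differs from compound 1 on another ring, (sulfamoyl in place of hydrogen on an aromatic carbon), and in this assay compound 3 gives 91.1%; the step of a number 3 percentage points higher from compound 1 to compound 3 (within the scatter).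

Compound 4, `COc1ccc(-c2cc(-c3ccc4cc(F)ccc4n3)n(-c3ccc(S(N)(=O)=O)cc3)n2)cc1`, has not been measured in this assay. It stands to compound 3 as compound 2 stands to compound 1: the change is methoxy in place of fluoro on an aromatic carbon, and since the place reads the same word for word in both pairs, it is the same change, made once on the core of compound 1 and once on the core of compound 3, whose cores differ by sulfamoyl in place of hydrogen on an aromatic carbon.

Going by the values given here, the only guide is the step from compound 1 to compound 2, a number 15.9 percentage points higher from compound 1 to compound 2 (beyond the scatter). Compound 4 is therefore expected to move from compound 3 by a similar amount, a number 13.9 percentage points higher from compound 3 to compound 4 (beyond the scatter), because the same change on compound 1 gave a number 15.9 percentage points higher from compound 1 to compound 2 (beyond the scatter), while the core difference itself left a number 3 percentage points higher from compound 1 to compound 3 (within the scatter). Compound 4 is estimated at 105%, with a plausible range from 93% to 118%; with two examples only, this expectation rests on a single measured step.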

Compound 4, a percentage reported as activity, at one concentration (the size of the read-out at that concentration, not a potency): 83.7%
Compound 4: the middle estimate sits 21.3 percentage points above what was measured, and the stated range ends above it.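

In this assay, the change from 4-fluorophenyl to 4-methoxyphenyl does not carry over from the core of compound 1 to the core of compound 3, where it gives a number 7.4 percentage points lower from compound 3 to compound 4 (within the scatter), and the two steps do not agree: the same change on two cores in this assay, a number 15.9 percentage points higher (beyond the scatter) from compound 1 to compound 2 and a number 7.4 percentage points lower (within the scatter) from compound 3 to compound 4, 23.3 percentage points apart, beyond the scatter of two such steps

The same four compounds show this from the other side, since sulfamoyl in place of hydrogen, with methoxy present, gives a number 20.3 percentage points lower from compound 2 to compound 4 (beyond the scatter), and that step does not match the one seen with fluoro present: the same change on two cores in this assay, a number 3 percentage points higher (within the scatter) from compound 1 to compound 3 and a number 20.3 percentage points lower (beyond the scatter) from compound 2 to compound 4, 23.3 percentage points apart, beyond the scatter of two such steps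

This shows that, among these four compounds, the two changes do not simply add, so a step measured on one core is a poor guide to the other; it rests on a single set of four compounds, however, and does not show why the steps differ or whether the same would hold for other groups or cores.

The compounds shown leave open whether an amine or a methyl group in place of the methoxy would also behave differently on the two cores, and whether a carboxylic acid in place of sulfamoyl would do the same. With a read-out at one concentration only, they also leave open how these compounds would compare across a range of concentrations.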